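Compound 3 to compound 4: isopropyl to ethyl

This account rests on a few compounds, and the source may have more. Where it says the series, first, only, none or still open, it means among the compounds named here.

In a functional assay on HCT-116 cells (Homo sapiens) for cytotoxicity, read by sulforhodamine B assay, with a stated time of 72 h (a lower number here means a stronger inhibitor, a higher number a weaker inhibitor), compound 3 `CSC(=O)c1c(O[C@@H]2O[C@H](COC(C)=O)[C@@H](O)[C@H](O)[C@H]2O)c(C)c(O)c(C)c1C(C)C` gives > 40000 nM, which is a limit and not a number. Compound 1 `CSC(=O)c1c(O[C@@H]2O[C@H](CO)[C@@H](O)[C@H](O)[C@H]2O)c(C)c(O)c(C)c1C(C)C` gives > 40000 nM, also a limit. Compound 2 `CCc1c(C)c(O)c(C)c(O[C@@H]2O[C@H](CO)[C@@H](O)[C@H](O)[C@H]2O)c1C(=O)SC` gives > 40000 nM, again a limit. For the measured compounds named here, the series so far therefore reads as one entry: the limit of > 40000 nM in this assay, at which 3 of the 3 values shown sit.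

Compound 4 `CCc1c(C)c(O)c(C)c(O[C@@H]2O[C@H](COC(C)=O)[C@@H](O)[C@H](O)[C@H]2O)c1C(=O)SC` is reached from compound 3 by hydrogen in place of methyl on a saturated chain carbon bound to an aromatic carbon and a saturated chain carbon, with hydrogen in place of methyl on a saturated chain carbon bound to an aromatic carbon and a saturated chain carbon, that is, isopropyl to ethyl.

The same replacement has been measured once, as a step that the two limits leave unreadable from compound 1 to compound 2. The acetyl on compound 3 is the other measured change, seen as a step that the two limits leave unreadable from compound 1 to compound 3. Neither gives a size, so nothing supports a shift beyond the scatter in this assay, and another limit is the likely report.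

The expected change is a step that the limit leaves unreadable from compound 3 to compound 4. Compound 4 is estimated at 50000 nM, with an expected range of 30000 nM to 100000 nM.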

Compound 4, half-maximal inhibitory concentration: > 40000 nM
Compound 4 gave a limit, no number (the forecaster's own chance of this, stated with the estimate: 90%); the middle value lies beyond the limit too.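

Compound 4 gives a limit, as do compound 2 and compound 3, so neither new step, from compound 3 or from compound 2 to compound 4, can be read. The compounds shown leave open what size the isopropyl to ethyl change and the acetyl have in this assay, and the series still reads as one entry: the limit of > 40000 nM in this assay, at which 4 of the 4 values shown sit.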